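This account rests on a few compounds, and the source may have more. Where it says the series, first, only, none or still open, it means among the compounds named here.

Measured in a functional assay on U-251 cells (Homo sapiens) for cytotoxicity; on this read-out lower numbers stand for stronger inhibition of growth and higher numbers for weaker inhibition of growth:
compound 1 `COc1ccc(C2=C(c3ccc(SC)cc3)CC3CCCN3C2=O)cc1O`: 5000 nM
compound 2 `CSc1ccc(C2=C(c3ccc(F)c(F)c3)C(=O)N3CCCC3C2)cc1`: 15000 nM

Compound 1 has the lower of the two numbers, and compound 2 lies beyond the scatter from it. Compound 3 `COc1ccc(C2=C(c3ccc(SC)cc3)CC3CCCN3C2=O)cc1OC` keeps the core of compound 1 and differs in one place: methyl in place of hydrogen on an oxygen on an aromatic ring, or hydroxy to methoxy. Among the measured compounds shown here, only one measured step bears on this change, the modest 3.0-fold higher number from compound 1 to compound 2 (0.48 log units; beyond the scatter), with 3,4-difluorophenyl in place of 3-hydroxy-4-methoxyphenyl. For the measured compounds named here, that step also removes the hydroxy, but it replaces the whole aryl group, and no measured pair shows the hydroxy to methoxy change alone. A smaller move in the same direction, toward a higher number, is therefore expected in this assay, and it may not exceed the scatter. The expected step is a 1.6-fold higher number from compound 1 to compound 3 (0.20 log units; within the scatter). Compound 3 is estimated at 8000 nM, with an expected range from 3000 nM to 25000 nM.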

Compound 3, concentration for 50% growth inhibition: 300 nM
Estimate against measurement, compound 3: 27-fold (1.43 log units) above; measured number below the stated range.
By their numbers in this assay, from the lowest: compound 3; then compound 1; then compound 2.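

In this assay, the hydroxy to methoxy change proves to be a large step on its own, a 17-fold lower number from compound 1 to compound 3 (1.22 log units; beyond the scatter), and it runs toward stronger inhibition of growth. The earlier step, a 3.0-fold higher number from compound 1 to compound 2 (0.48 log units; beyond the scatter), replaced the whole aryl group and so could not separate the hydroxy from the rest of that group; this pair alters only one place, with methyl in place of hydrogen on an oxygen on an aromatic ring, and shows that this single position can by itself shift the read-out strongly on the core of compound 1. Nothing given here explains the size or direction of the step.

The compounds shown leave open whether the gain depends on methyl in particular or would persist with a longer chain such as ethoxy, or with an amine in place of the oxygen. They also leave open whether the same change would give a step of similar size if the other aryl group on the shared core were replaced.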